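Compound 2 to compound 4: replacing 1-methoxycycloheptyl

The source may hold more compounds than are shown below. What is called first, only, known or untested is meant among the compounds shown, and "the series" means these compounds.

Compounds measured in an ADME assay on microsomes from liver (Mus musculus) for metabolic stability, with a stated time of 10 min; on this read-out lower numbers stand for a less stable compound and higher numbers for a more stable compound:
- Compound 1 `Cc1c(Cl)cccc1Oc1cccn2c(C34CCC(CC3)C4)nnc12`: 57%
- Compound 2 `COC1(c2nnc3c(Oc4cccc(Cl)c4C)cccn23)CCCCCC1`: < 1%
- Compound 3 `Cc1c(Cl)cccc1Oc1cccn2c([C@]34CCC(C[C@H]3O)C4(C)C)nnc12`: 21%

Compound 2 reads < 1%, which is a limit of the assay and not a number. It stands at the limit of < 1% in this assay, at which 1 of the 3 values shown sits. Compound 4 `Cc1c(Cl)cccc1Oc1cccn2c(C3CCC(C)(O)CC3)nnc12` has not yet been measured, and it differs from compound 2 by 4-hydroxy-4-methylcyclohexyl in place of 1-methoxycycloheptyl on an aromatic carbon. In these words, 4-hydroxy-4-methylcyclohexyl stands in place of 1-methoxycycloheptyl on an aromatic carbon.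

Going by the values given here, one measured step bears directly on this change, as it brought in the same 1-methoxycycloheptyl group at the same place: a number at least 56 percentage points lower from compound 1 to compound 2 (beyond the scatter). That step was large, and the group it introduced is the one that leaves here, so a large step upward is expected in this assay. A return all the way to the level of compound 1 at 57% is not assumed, as compound 4 does not regain that group. Compound 3 also carries a hydroxy group on its saturated carbon rings, and compound 3 gives 21%, which tempers the expectation. The expected change is a number at least 32 percentage points higher from compound 2 to compound 4 (beyond the scatter). For compound 4 the estimated value is 33%, with an expected range from 10% to 65%.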

Compound 4, percent of the compound remaining: 97%
Compound 4: the middle estimate sits 64 percentage points below what was measured; the whole stated range lies below it.
By their numbers in this assay, from the lowest: compound 3; then compound 1; then compound 4. At a limit, below all of these: compound 2.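

In this assay, moving from 1-methoxycycloheptyl to 4-hydroxy-4-methylcyclohexyl on this aromatic carbon of the five-membered ring gives a number at least 96 percentage points higher from compound 2 to compound 4 (beyond the scatter). The same group also exceeds the group with two five-membered carbon rings, with a number 40 percentage points higher from compound 1 to compound 4 (beyond the scatter), so at this place a six-membered carbon ring bearing a hydroxy group can read well above a hydrocarbon group with no oxygen. Compound 2 reads < 1%, which is a limit of the assay and not a number, so the first step has only a lower bound: the limit of < 1% in this assay, at which 1 of the 4 values shown sits.

The compounds shown do not separate the parts of the change from compound 2 to compound 4, since the methoxy group, the ring size, the hydroxy group and the methyl group all differ at once, and none of these is varied alone. They also leave open whether the reading would hold with an amine or a carboxylic acid in place of the hydroxy group on the six-membered ring, or with a plain cyclohexyl group at this place.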